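Swapping bromo for ethoxymethyl on an aromatic carbon

The source may hold more compounds than are shown below. What is called first, only, known or untested is meant among the compounds shown, and "the series" means these compounds.

Within the data shown here, in a functional assay on MES-SA/Dx5 cells (Homo sapiens) for inhibition, with a stated time of 72 h, in the presence of a further agent that is not named here (on this read-out higher numbers stand for weaker inhibition and lower numbers for stronger inhibition), three compounds have numbers so far. Compound 1 `CCN(CC)Cc1ccc2cccnc2c1O` gives 3040 nM; 3020 nM (2 entries) and compound 2 `Oc1c(CN2CCCCC2)ccc2cccnc12` gives 2690 nM; 2750 nM (2 entries), each from two entries that agree closely. Among the measured compounds shown here, compound 3 `Oc1c(CN2CCCC2)cc(Br)c2cccnc12` gives 2690 nM, its only single number, alongside two further entries without one. These three values lie within the usual scatter of one another, so compound 3 stands level with the other two and no ranking can be drawn.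

The next compound, compound 4 `CCOCc1cc(CN2CCCC2)c(O)c2ncccc12`, carries ethoxymethyl in place of the bromo of compound 3: ethoxymethyl in place of bromo on an aromatic carbon. The swap sits on an aromatic carbon, para to a hydroxy group and meta to a (pyrrolidin-1-yl)methyl group. For the measured compounds named here, no two measured compounds differ in just one place, so no measured step shows what such a swap does in this assay. Going by the values given here, the only guide is the narrow band of values, with compound 3 at 2690 nM and compound 1 at 3040 nM; 3020 nM (2 entries). The expectation is therefore no step beyond the scatter, with only a slight lean towards weaker inhibition. The expected change a 1.2-fold higher number from compound 3 to compound 4 (0.08 log units; within the scatter) is small. Compound 4 is estimated at 3200 nM, with an expected range of 1300 nM to 7500 nM.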

Compound 4, half-maximal inhibitory concentration: 5250 nM
Estimate against measurement, compound 4: 1.6-fold (0.22 log units) below, and the stated range covers the measured number.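

In this assay, among these compounds, this is the first step between two compounds that differ in only one place, and it reads a 2.0-fold higher number from compound 3 to compound 4 (0.29 log units; within the scatter). Among the compounds shown here, at this aromatic carbon, para to a hydroxy group, bromo with its 1 heavy atom and no hydrogen-bond acceptor can therefore give way to ethoxymethyl with its 4 heavy atoms and 1 hydrogen-bond acceptor without a step beyond the scatter, which the earlier compounds could not show. Repeat entries of one compound agree much more closely than this step does, yet a single step within the scatter cannot establish a real loss of inhibition: the several entries of compound 1 in this assay, 3040 nM; 3020 nM (2 entries)

Going by these compounds, one swap cannot separate the roles of the added heavy atoms and the hydrogen-bond acceptor, so it remains open whether a primary amine, a carboxylic acid or a longer alkyl chain on this carbon would give a step beyond the scatter. On these data alone, it is also open whether ethoxymethyl in place of bromo would read the same with the diethylamino group of compound 1 in place of the (pyrrolidin-1-yl)methyl group.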